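A Methyl-to-Nitro Swap Tested for Cytotoxicity

This account rests on a few compounds, and the source may have more. Where it says the series, first, only, none or still open, it means among the compounds named here.

Of the compounds shown here, two sharing one core have so far been measured in a functional assay on MCF7 cells (Homo sapiens) for cytotoxicity, read by sulforhodamine B assay, with a stated time of 72 h; on this read-out higher numbers stand for weaker inhibition and lower numbers for stronger inhibition. Compound 1 `Cc1c(-c2csc(NC(=S)Nc3ccccc3)n2)c(=O)n(-c2ccccc2)n1C` gives 10100 nM in this assay. Compound 2 `CC(=O)c1nn(-c2ccc(C)cc2)/c(=N/c2nc(-c3c(C)n(C)n(-c4ccccc4)c3=O)cs2)s1` gives 56800 nM in this assay; of the two numbers recorded, that of compound 2 is the higher, and the gap separating it from compound 1 lies beyond the usual scatter. The next compound, compound 3 `CC(=O)c1nn(-c2ccc([N+](=O)[O-])cc2)/c(=N/c2nc(-c3c(C)n(C)n(-c4ccccc4)c3=O)cs2)s1`, differs from compound 2 in a single place: nitro in place of methyl on an aromatic carbon, or, cut one bond further out, 4-methylphenyl to 4-nitrophenyl. Among the compounds with values here, no measured pair in this set shows what such a swap does in this assay, so nothing about its size can be read from the data. With no guidance from the numbers, the expected step from compound 2 to compound 3 is a 1.3-fold lower number from compound 2 to compound 3 (0.10 log units; within the scatter), which means nothing beyond the scatter in either direction. Compound 3 is therefore estimated at 45000 nM in this assay, with a range from 15000 nM to 130000 nM.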

Compound 3, half-maximal inhibitory concentration: > 100000 nM
Compound 3: a limit, no number; the forecaster's own chance of this, stated with the estimate: 15%; middle value at least 2.2-fold (0.34 log units) from the limit.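

In this assay, compound 3 carries a limit of the assay and not a number: the limit of > 100000 nM in this assay, at which 1 of the 3 values shown sits. Within the data shown here, the swap of 4-methylphenyl to 4-nitrophenyl, on an aromatic carbon para to a large group, is read as an at least 1.7-fold higher number from compound 2 to compound 3 (0.24 log units; that floor lies within the scatter), which is the first view of this position, since no earlier pair touched it. Nitro in place of methyl there therefore brought no sign of stronger inhibition on this read-out, although the true size of the step stays unknown and only its floor is fixed, with that floor still inside the usual scatter.

The compounds shown leave open whether this result is particular to nitro or would hold for other groups at the same place, such as an amine, a methoxy group, a chlorine atom or a carboxylic acid. They also leave open how the same place would read with a bare hydrogen in place of methyl, a comparison that would give the methyl of compound 2 a reference of its own.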